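A few compounds are considered here, and "the series" means these few. Any claim that something is new, unique, unknown or untested is made for them only; others in the source may bear on it.

Working notes on the series. In a functional assay on CHO cells for positive allosteric modulation of metabotropic glutamate receptor 2 (Homo sapiens), with a stated time of 30 min (a higher number here means that more compound is needed for the effect, a lower number that less compound is needed), compound 1, `CC(C)Cn1ccc(N2CCC(c3ccccc3)CC2)c(C#N)c1=O`, gives 282 nM. Compound 2, `N#Cc1c(N2CCC(c3ccccc3F)CC2)ccn(CC2CC2)c1=O`, gives 81 nM in this assay. Of the two numbers measured, compound 2 has the lowest; its nearest neighbour is compound 1, whose number is higher by a margin that falls beyond the usual scatter. Compound 3, `N#Cc1c(N2CCC(c3ccc(F)cc3)CC2)ccn(CC2CC2)c1=O`, has not yet been measured. It differs from compound 2 in a single place: 4-fluorophenyl in place of 2-fluorophenyl on a saturated ring carbon. Among the compounds with values here, no measured pair shows the effect of moving a fluorine on this phenyl ring, so there is no step to lean on. The change keeps the same atoms and moves only the fluorine, so the expected step in this assay from compound 2 is a 1.5-fold higher number from compound 2 to compound 3 (0.17 log units; within the scatter), which is estimated as none beyond the scatter. Compound 3 is therefore estimated at 120 nM in this assay, within a range from 40 nM to 400 nM.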

Compound 3, half-maximal effective concentration: 89 nM
For compound 3 the middle estimate is 1.3-fold (0.13 log units) above the measured one; the measured number falls inside the stated range.
By their numbers in this assay, from the lowest: compounds 2 and 3 (each within the scatter of the next); then compound 1.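

Moving the fluorine, with 4-fluorophenyl in place of 2-fluorophenyl on the saturated ring carbon, gives a 1.1-fold higher number from compound 2 to compound 3 (0.04 log units; within the scatter) in this assay. Within the data shown here, this is the first pair that differs in a single place, and it shows that, for these two fluorophenyl groups, the number does not depend on where the fluorine sits on the phenyl ring. Nothing at hand accounts for this result.

Among these compounds, what the fluorine itself contributes stays open, since compound 1 differs from compound 2 in more than one place and gives no clean step. Also open, going by these compounds, is whether this phenyl ring would hold the number with a methoxy group or a chlorine atom in place of the fluorine.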